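The source may report more compounds than this note shows. Statements on the series, on what has been measured and on what is new or still open speak of the compounds shown alone.

Working notes on the series. Among the measured compounds shown here, compound 2 `CNC(=O)N1CCCc2ccc(NC(=O)c3ccc(-c4cccnc4)cc3)cc21` stands highest of the two numbers measured so far in a functional assay on MV4-11 cells (Homo sapiens) for antiproliferative activity, with a stated time of 6 days, tested at 6.25 uM; a higher number here means a stronger effect of the compound at the concentration tested, a lower number a weaker effect: compound 2 gives 92.1%. Its nearest neighbour is compound 1 `CNC(=O)N1CCCc2ccc(NC(=O)c3ccc(-c4ccccn4)cc3)cc21`, which in this assay gives 79.2%, and the gap between them is beyond the scatter. For the measured compounds named here, the single measured step is a number 12.9 percentage points higher from compound 1 to compound 2 (beyond the scatter), a modest rise for pyridin-3-yl in place of pyridin-2-yl on an aromatic carbon.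

Compound 3 `CNC(=O)N1CCCc2ccc(NC(=O)c3ccc(-c4cnn(S(C)(=O)=O)c4)cc3)cc21` has not yet been measured. It differs from compound 2 by 1-(methylsulfonyl)-1H-pyrazol-4-yl in place of pyridin-3-yl on an aromatic carbon. Going by the values given here, the one measured step bears on this change only loosely: it exchanged one six-membered aromatic ring for another at the same place, whereas here a five-membered aromatic ring carrying a methylsulfonyl enters. Among the compounds with values here, with compound 2 already at 92.1%, there is little room for a further rise in this assay, and a small drop is as plausible as no step at all. The expected step is a number 12.1 percentage points lower from compound 2 to compound 3 (beyond the scatter). Compound 3 is therefore estimated at 80%, with a range from 55% to 97%.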

Compound 3, a percentage reported as inhibition, at one concentration (the size of the read-out at that concentration, not a potency): 40.2%
Estimate against measurement, compound 3: 39.8 percentage points above; the whole stated range lies above it.
By their numbers in this assay, from the lowest: compound 3; then compound 1; then compound 2.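

In this assay, the place on the six-membered aromatic ring of carbon only, para to a large group, proves far more sensitive than the two pyridines suggested: 1-(methylsulfonyl)-1H-pyrazol-4-yl in place of pyridin-3-yl gives a number 51.9 percentage points lower from compound 2 to compound 3 (beyond the scatter) and in place of pyridin-2-yl gives a number 39 percentage points lower from compound 1 to compound 3 (beyond the scatter) as the two large steps, whereas the exchange between the pyridines gave only a number 12.9 percentage points higher from compound 1 to compound 2 (beyond the scatter) as a modest one. The drop therefore appears from either pyridine, so it is not tied to one particular pyridine as the starting point. No evidence is available on what underlies this drop.

The five-membered aromatic ring and the methylsulfonyl enter together in compound 3, so the compounds shown leave open whether the drop goes with the ring, with the methylsulfonyl or with the two combined, and a 1-methyl-1H-pyrazol-4-yl or an unsubstituted 1H-pyrazol-4-yl at this place would help to separate them. Also open, going by these compounds, is how this place responds to a pyridin-3-yl carrying a small amine or a carboxylic acid, which would show whether a six-membered aromatic ring keeps its number with a further group attached.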